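The compounds below may be only part of what the source reports. "The series", "measured", "known", "first", "only" and "open" are said of these compounds alone.

Compound 1 `COC(=O)N1N=C(c2cccc(O)c2)CC1c1cc(OC)c(OC)c(OC)c1`: 810 nM
Compound 2 `CCOC(=O)N1N=C(c2cccc(O)c2)CC1c1cc(OC)c(OC)c(OC)c1`: 9750 nM

Both values come from a functional assay on A2780 cells (Homo sapiens) for antiproliferative activity, read by MTT assay, with a stated time of 48 h; a lower number here means a stronger inhibitor of growth, a higher number a weaker inhibitor of growth. Going by the values given here, compound 2 has the higher number of the two, which makes it the weaker inhibitor of growth, and compound 1 is its only neighbour. Compound 3 `CCCOC(=O)N1N=C(c2cccc(O)c2)CC1c1cc(OC)c(OC)c(OC)c1` differs from compound 2 by one change, ethoxy to propoxy: methyl in place of hydrogen on a saturated chain carbon, two bonds along the chain from an oxygen next to a carbonyl group. One measured step is of the same kind, methyl in place of hydrogen on a saturated chain carbon, and it was large: a 12-fold higher number from compound 1 to compound 2 (1.08 log units; beyond the scatter). That single step sat on the carbon bound to the oxygen, whereas the new methyl sits one carbon further out, so a further rise in this assay is expected, though a smaller one. The estimate amounts to an expected 1.5-fold higher number from compound 2 to compound 3 (0.19 log units; within the scatter). For compound 3 the expected value is 15000 nM, within an estimated range of 4500 nM to 50000 nM.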

Compound 3, concentration for 50% growth inhibition: 11100 nM
Compound 3: middle estimate off by 1.4-fold (0.13 log units), on the high side, within the range that was stated.
By their numbers in this assay, from the lowest: compound 1; then compounds 2 and 3 (each within the scatter of the next).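

In this assay, the added methyl, two bonds along the chain from an oxygen next to a carbonyl group, gives a 1.1-fold higher number from compound 2 to compound 3 (0.06 log units; within the scatter), so the change from ethoxy to propoxy does not separate these two compounds. Among these three compounds, the large change therefore comes with the first added carbon and not the second: a 12-fold higher number from compound 1 to compound 2 (1.08 log units; beyond the scatter), and the ethyl in place of hydrogen on the carbon bound to that oxygen gives a 14-fold higher number from compound 1 to compound 3 (1.14 log units; beyond the scatter). Nothing available here bears on the reason for this pattern.

As far as these compounds go, it remains open whether a longer chain such as butoxy would give a number like that of compound 3, or whether a chain carrying an amine would come closer to compound 1. From the compounds shown here alone, whether the same chain changes behave alike with other groups on the shared core also remains open.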